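A few compounds are considered here, and "the series" means these few. Any claim that something is new, unique, unknown or untested is made for them only; others in the source may bear on it.

Measured compounds: compound 1 `OC1CNCCC1N1CCN(c2ccccc2)CC1`, compound 2 `OC1CCN(Cc2cccc(Br)c2)CC1N1CCN(c2ccccc2)CC1`, compound 3 `CCN1CCC(O)C(N2CCN(c3ccccc3)CC2)C1`.

In an assay on PC-12 cells for displacement of a labelled ligand from vesicular acetylcholine transporter (Homo sapiens) (on this read-out lower numbers stand for stronger inhibition and higher numbers for weaker inhibition), compound 1 gives 100 nM. Compound 2 gives 46 nM. For compound 3 the read-out is only a limit of the assay, > 1000 nM, so compound 3 sits at the weak end of the values shown. Among the measured compounds shown here, the one measured step that ends at compound 3, an at least 21-fold higher number from compound 2 to compound 3 (1.33 log units; beyond the scatter), ran into (the limit of > 1000 nM in this assay, at which 1 of the 3 values shown sits).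

Compound 4 `C#CCN1CCC(O)C(N2CCN(c3ccccc3)CC2)C1` differs from compound 3 by ethynyl in place of methyl on a saturated chain carbon bound to an amine nitrogen in a ring. For the measured compounds named here, only that step bears on this change, and it swapped a different group; no measured step compares ethynyl with methyl at this carbon. Compound 4 is therefore expected to show a step that the limit leaves unreadable from compound 3 to compound 4, which remains within the scatter. Compound 4 is estimated at 1200 nM, with a range from 300 nM to 5000 nM.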

Compound 4, half-maximal inhibitory concentration: > 100 nM
Compound 4: no number, only a limit (the forecaster's own chance of this, stated with the estimate: 55%); the middle value does not contradict the limit.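

In this assay compound 4 gives > 100 nM as a limit and not a number. Ethynyl in place of 3-bromophenyl on this carbon gives an at least 2.1-fold higher number from compound 2 to compound 4 (0.33 log units; beyond the scatter) and so, like methyl, does not hold the value of compound 2, which makes propargyl a second small group on the ring nitrogen to end in a limit. Methyl and ethynyl cannot be ordered, as the step between compound 3 and compound 4 cannot be read with both values being limits.

Still open, from the compounds shown here alone, is how a plain phenyl or a longer chain ending in an amine at this carbon would read in this assay against the 3-bromophenyl of compound 2.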